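Replacing Trifluoromethyl with Chloro-Methoxy on the Outer Ring

A few compounds are considered here, and "the series" means these few. Any claim that something is new, unique, unknown or untested is made for them only; others in the source may bear on it.

Compound 2 `CC[C@@H](Nc1c(C#N)c(-c2ccc(-c3ccccc3C(F)(F)F)cc2)nc2cnccc12)C(N)=O` gives 3.1 in a physicochemical assay for lipophilicity, read by HPLC, at pH 7.5 (on this read-out higher numbers stand for higher lipophilicity and lower numbers for lower lipophilicity), the second highest of the three numbers recorded: compound 1 `CCCCC(Nc1c(C#N)c(-c2ccc(-c3ccccc3OCC)cc2)nc2cnccc12)C(N)=O` gives 3.6 in this assay, and compound 3 `CCOc1ccccc1-c1ccc(-c2nc3cnccc3c(N[C@H](CC)C(=O)NS(=O)(=O)C3CC3)c2C#N)cc1` gives 2.3. For the measured compounds named here, the one measured step, a number 1.30 log units lower from compound 1 to compound 3 (beyond the scatter), concerns the amide side of the shared core and not the outer aryl ring, so no measured step bears directly on the change to compound 4 `CC[C@@H](Nc1c(C#N)c(-c2ccc(-c3cccc(Cl)c3OC)cc2)nc2cnccc12)C(N)=O`: 3-chloro-2-methoxyphenyl in place of 2-(trifluoromethyl)phenyl on an aromatic carbon. With nothing in the data to point either way, the estimate for compound 4 in this assay is a step of a number 0.10 log units lower from compound 2 to compound 4 (within the scatter), within the scatter. Compound 4 is therefore expected to give about 3, between 2.6 and 3.4.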

Compound 4, distribution coefficient: 3.1
For compound 4 the middle estimate is 0.10 log units below the measured one; the measured number falls inside the stated range.
By their numbers in this assay, from the lowest: compound 3; then compounds 2 and 4 (each within the scatter of the next); then compound 1.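

In this assay, for the compounds shown here, the step of no change at the digits printed from compound 2 to compound 4 (within the scatter) is the first measured change on the outer aryl ring, as the earlier step concerned only the amide side of the shared core. It shows that at this position 3-chloro-2-methoxyphenyl can take the place of 2-(trifluoromethyl)phenyl, bringing in one hydrogen-bond acceptor, with the read-out staying within the scatter. Nothing available accounts for this result. On these data alone, whether an outer ring carrying an amine or a carboxylic acid would stay within the scatter remains open.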